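Toward Compound 4: Trading the Hydrazide for an Ester

A few compounds are considered here, and "the series" means these few. Any claim that something is new, unique, unknown or untested is made for them only; others in the source may bear on it.

Compound 3 `NNC(=O)COc1ccncc1-c1ccc2ccccc2c1` gives 19% in an assay on a protein complex for inhibition of CDK8/Cyclin C (Homo sapiens), with a stated time of 1 h, tested at 10 uM (a lower number here means less inhibition, a higher number more inhibition at the concentration tested (going by the name of the read-out)), the second highest of three numbers. Compound 1 `CNC(=O)CCc1ccncc1-c1ccc2ccccc2c1` gives 100%, and compound 2 `CNC(=O)COc1ccncc1-c1ccc2ccccc2c1` gives 4%. The steps of a number 81 percentage points lower from compound 1 to compound 3 (beyond the scatter) and a number 96 percentage points lower from compound 1 to compound 2 (beyond the scatter) are both large, whereas a number 15 percentage points higher from compound 2 to compound 3 (beyond the scatter) is modest. Compound 4 `COC(=O)CCc1ccncc1-c1ccc2ccccc2c1` differs from compound 3 as follows: 2-(methoxycarbonyl)ethyl in place of (aminocarbamoyl)methoxy on an aromatic carbon. The two large steps bear on this change because compound 1 with its 2-(methylcarbamoyl)ethyl chain gives 100%, while both chains carrying a methoxy give low numbers. Going by the values given here, no measured step shows how a methoxycarbonyl compares with a carbamoyl group, so some uncertainty remains. Compound 4 is expected to lie higher, with the expected step being a number 56 percentage points higher from compound 3 to compound 4 (beyond the scatter). The estimate for compound 4 is 75%, within a range from 40% to 98%.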

Compound 4, a percentage reported as inhibition, at one concentration (the size of the read-out at that concentration, not a potency): 98%
The estimate for compound 4 lay 23 percentage points below the measured number; the range from low to high includes it.
By their numbers in this assay, from the lowest: compound 2; then compound 3; then compounds 4 and 1 (each within the scatter of the next).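

In this assay, methoxy can replace methylamino on the carbonyl carbon with no change beyond the scatter, as shown by a number 2 percentage points lower from compound 1 to compound 4 (within the scatter) and so a 2-(methoxycarbonyl)ethyl chain with no hydrogen-bond donors serves as well as the amide chain. The high numbers at this position therefore do not depend on the methylamino end, and the gaps remain large with a number 79 percentage points higher from compound 3 to compound 4 (beyond the scatter) and with a number 94 percentage points higher from compound 2 to compound 4 (beyond the scatter) in the same assay. Nothing available explains these differences. Going by these compounds, whether a carboxylic acid or a longer chain at this position would hold the number stays open.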